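This account rests on a few compounds, and the source may have more. Where it says the series, first, only, none or still open, it means among the compounds named here.

- compound 1 `C=C1C=CC(=O)[C@@H]2[C@H](Cc3ccc(OCOC)c(F)c3)CC[C@H]12` gives 77.4 nM
- compound 2 `C=C1C=CC(=O)[C@@H]2[C@H](Cc3ccc(F)c(F)c3)CC[C@H]12` gives 235 nM

In a functional assay on HCT-116 cells (Homo sapiens) for antiproliferative activity, with a stated time of 72 h (a higher number here means a weaker inhibitor, a lower number a stronger inhibitor), compound 2 gives 235 nM and so holds the higher of the two numbers, making it the weaker inhibitor. Compound 3 `C=C1C=CC(=O)[C@@H]2[C@H](Cc3ccc(OC)c(F)c3)CC[C@H]12` alters compound 2 at one place (methoxy in place of fluoro on an aromatic carbon) with methoxy in place of fluoro on an aromatic carbon, ortho to a fluoro group. Among the measured compounds shown here, one measured step bears on this: a 3.0-fold higher number from compound 1 to compound 2 (0.48 log units; beyond the scatter), where fluoro replaced methoxymethoxy on that same carbon. Read backwards, that step points to a lower number, but methoxy is not methoxymethoxy, so a somewhat smaller change is expected. The expected change is a 2.1-fold lower number from compound 2 to compound 3 (0.33 log units; beyond the scatter) in this estimate. For compound 3 the estimated value is 110 nM with an expected range from 55 nM to 240 nM in this test.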

Compound 3, half-maximal inhibitory concentration: 1.11 nM
Estimate against measurement, compound 3: 99-fold (2.00 log units) above, outside the stated range (below it).
By their numbers in this assay, from the lowest: compound 3; then compound 1; then compound 2.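

In this assay, the group on this aromatic carbon, para to a large group, matters far more than the earlier pair suggested: methoxy in place of fluoro gives a 210-fold lower number from compound 2 to compound 3 (2.33 log units; beyond the scatter) and is the largest change seen here. Shortening methoxymethoxy to methoxy also gives a 70-fold lower number from compound 1 to compound 3 (1.84 log units; beyond the scatter), so the two oxygen-bearing groups are far from interchangeable at this position. Nothing available explains this jump. On these data alone, whether an ethoxy group or a hydroxyl on this carbon would match methoxy stays open, as does what the fluoro group ortho to it contributes.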